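Amide variants at the carbonyl carbon: expectation for compound 4

The compounds below may be only part of what the source reports. "The series", "measured", "known", "first", "only" and "open" are said of these compounds alone.

Three compounds share one core and differ only at a carbonyl carbon whose other neighbour is an aromatic carbon. Compound 1 `COc1cc(-n2cccc2C(=O)O)ccc1Nc1ncc(Cl)c(Nc2ccccc2NS(C)(=O)=O)n1` carries a hydroxy there, and in a functional assay on NCI-H2228 cells (Homo sapiens) for antiproliferative activity, read by MTT assay, with a stated time of 72 h (on this read-out higher numbers stand for weaker inhibition and lower numbers for stronger inhibition), compound 1 gives 640 nM. Compound 2 `CCN1CCN(C(=O)c2cccn2-c2ccc(Nc3ncc(Cl)c(Nc4ccccc4NS(C)(=O)=O)n3)c(OC)c2)CC1` carries 4-ethylpiperazin-1-yl, and in this assay compound 2 gives 1130 nM. Compound 3 `COc1cc(-n2cccc2C(=O)N2CCCC2)ccc1Nc1ncc(Cl)c(Nc2ccccc2NS(C)(=O)=O)n1` carries pyrrolidin-1-yl, and in this assay compound 3 gives 600 nM. On the numbers compound 2 sits at the top of the three, but this position is not secured: a 1.8-fold higher number from compound 1 to compound 2 (0.25 log units; within the scatter) and a 1.9-fold lower number from compound 2 to compound 3 (0.27 log units; within the scatter) both fall within the scatter, as does a 1.1-fold lower number from compound 1 to compound 3 (0.03 log units; within the scatter), so the three substituents at this carbon are not separated by the data.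

Compound 4 `COc1cc(-n2cccc2C(=O)N2CCC(C)CC2)ccc1Nc1ncc(Cl)c(Nc2ccccc2NS(C)(=O)=O)n1` is unmeasured. Its change from compound 2 is 4-methylpiperidin-1-yl in place of 4-ethylpiperazin-1-yl on a carbonyl carbon. Among the measured compounds shown here, the steps that bear on this change are the two measured exchanges at the same carbonyl carbon, a 1.8-fold higher number from compound 1 to compound 2 (0.25 log units; within the scatter) and a 1.9-fold lower number from compound 2 to compound 3 (0.27 log units; within the scatter), and neither leaves the scatter. On that basis no step beyond the scatter is expected in this assay; the expected step is a 1.5-fold lower number from compound 2 to compound 4 (0.18 log units; within the scatter), a slight move toward compound 3. For compound 4 the estimate in this assay is 750 nM, with a range from 320 nM to 1800 nM.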

Compound 4, half-maximal inhibitory concentration: 1050 nM
Estimate against measurement, compound 4: 1.4-fold (0.15 log units) below; low and high end bracket the measured number.
By their numbers in this assay, from the lowest: compounds 3, 1, 4 and 2 (each within the scatter of the next).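

In this assay, the exchange of 4-ethylpiperazin-1-yl for 4-methylpiperidin-1-yl on the carbonyl carbon gives a 1.1-fold lower number from compound 2 to compound 4 (0.03 log units; within the scatter), so going from a six-membered ring with 2 hetero atoms and 1 hydrogen-bond acceptor to one with 1 hetero atom and 0 hydrogen-bond acceptors produces no readable step on this read-out. The fourth substituent is also not separated from the other two, with a 1.8-fold higher number from compound 3 to compound 4 (0.24 log units; within the scatter) and a 1.6-fold higher number from compound 1 to compound 4 (0.22 log units; within the scatter), so all four compounds now remain within the scatter of the next in line and no substituent at this carbon stands apart. Nothing at hand accounts for this flat picture.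

Still open, going by these compounds, is whether any group of another kind on this carbonyl carbon, such as morpholin-4-yl, a simple primary amide or an open dimethylamino group, or a longer chain in place of the ethyl on the piperazine, would produce a step beyond the scatter. On these data alone, all four compounds also keep the rest of the shared core unchanged, so it remains open whether the same lack of separation at this carbon would hold on a different core.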